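The compounds below may be only part of what the source reports. "The series", "measured", "known", "first", "only" and "open" are said of these compounds alone.

Measured compounds in an assay on isolated protein for displacement of a labelled ligand from metabotropic glutamate receptor 5 (Homo sapiens), with a stated time of 60 min, tested at 1 uM; on this read-out higher numbers stand for more inhibition at the one concentration tested (going by the name of the read-out) and lower numbers for less inhibition:
compound 1 `COc1ccc2ncc(S(=O)(=O)c3ccc(Cl)cc3)c(N3CCC(C)CC3)c2c1` gives 91%
compound 2 `COc1ccc2ncc(S(=O)(=O)c3cccc(C#N)c3)c(N3CCC(C)CC3)c2c1` gives 90%

On the numbers shown, compound 2 and compound 1 cannot be separated: the single measured step, a number 1 percentage points lower from compound 1 to compound 2 (within the scatter), lies within the scatter, so neither compound can be said to give the higher inhibition in this assay. Both aryl groups tried so far on the sulfonyl sulfur leave the inhibition in this assay near the top of the percentage scale.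

Compound 3 `COc1ccc2ncc(S(=O)(=O)c3ccc(OC)c(Cl)c3)c(N3CCC(C)CC3)c2c1` has not yet been measured in this assay. It differs from compound 2 in one place: 3-chloro-4-methoxyphenyl in place of 3-cyanophenyl on a sulfonyl sulfur. For the measured compounds named here, the only measured step that bears on this change is the exchange of the aryl group on the same sulfonyl sulfur, a number 1 percentage points lower from compound 1 to compound 2 (within the scatter), which stayed within the scatter. With two aryl variants at this position both giving high inhibition, a third variant is expected to behave alike. The expected step from compound 2 to compound 3 is therefore none beyond the scatter, a number 3 percentage points lower from compound 2 to compound 3 (within the scatter). Compound 3 is estimated at 87%, with a range from 68% to 96%; because compound 2 already gives 90% there is little room upward, so the range is widened downward. Going by the values given here, only two compounds support this expectation.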

Compound 3, a percentage reported as inhibition, at one concentration (the size of the read-out at that concentration, not a potency): 21%
Compound 3: the middle estimate sits 66 percentage points above what was measured; measured number below the stated range.
By their numbers in this assay, from the lowest: compound 3; then compounds 2 and 1 (each within the scatter of the next).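

In this assay the aryl group on the sulfonyl sulfur turns out not to be freely exchangeable: the change to 3-chloro-4-methoxyphenyl gives a number 69 percentage points lower from compound 2 to compound 3 (beyond the scatter) and likewise a number 70 percentage points lower from compound 1 to compound 3 (beyond the scatter) even though the exchange between the two earlier aryl groups gave only a number 1 percentage points lower from compound 1 to compound 2 (within the scatter) in the same assay. A chloro substituent on the ring does not by itself hold the inhibition at this position, as 4-chlorophenyl and 3-chloro-4-methoxyphenyl both carry one and still end far apart. Nothing available on these compounds accounts for the loss.

The compounds shown do not separate the part played by the methoxy group from that of the placement of the chlorine, and a plain 4-methoxyphenyl or 3-chlorophenyl on the same sulfur would pull these two apart. Also open, from the compounds shown here alone, is whether the loss stays when the methoxy of 3-chloro-4-methoxyphenyl gives way to a hydroxyl, an amine or a longer ethoxy chain, and whether it carries over to other amines on the shared core.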